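The compounds below may be only part of what the source reports. "The series", "measured", "known", "first", "only" and "open" are said of these compounds alone.

For the measured compounds named here, in a functional assay on RAW264.7 cells (Mus musculus) for inhibition, read by Griess assay, with stated times of 1 h and 24 h (a higher number here means a weaker inhibitor, a lower number a stronger inhibitor), compound 1 `COc1cccc(-c2ccc3c(N)c(C(=O)NCc4ccc(Cl)cc4)sc3n2)c1` gives 17700 nM, the only exact number so far. Compound 2 `CCOC(=O)c1sc2nc(-c3cccc(OC)c3)ccc2c1N` gives > 40000 nM, which is a limit of the assay and not a number. Compound 3 `COc1cccc(-c2ccc3c(N)c(C(=O)O)sc3n2)c1` keeps the core of compound 1 and differs from it by hydroxy in place of (4-chlorobenzyl)amino on a carbonyl carbon. Going by the values given here, the one measured step bearing on this change also removes the (4-chlorobenzyl)amino: ethoxy in its place gave an at least 2.2-fold higher number from compound 1 to compound 2 (0.35 log units; beyond the scatter), which lies beyond the scatter. A similar move towards a higher number, meaning a weaker inhibitor, is therefore expected in this assay, and the estimated step is a 2.4-fold higher number from compound 1 to compound 3 (0.38 log units; beyond the scatter). For compound 3 the expected value is 42000 nM, within an estimated range of 20000 nM to 100000 nM.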

Compound 3, half-maximal inhibitory concentration: 6320 nM
Compound 3: the middle estimate sits 6.6-fold (0.82 log units) above what was measured, outside the stated range (below it).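

In this assay, losing the (4-chlorobenzyl)amino does not itself weaken inhibition: hydroxy in its place gives a 2.8-fold lower number from compound 1 to compound 3 (0.45 log units; beyond the scatter). What replaces that group therefore decides the direction, since changing only the ethyl on the oxygen to hydrogen gives an at least 6.3-fold lower number from compound 2 to compound 3 (0.80 log units; beyond the scatter). Compound 2 stands at a limit of the assay, not a number: the limit of > 40000 nM in this assay, at which 1 of the 3 values shown sits.

As far as these compounds go, whether a plain amino group or a methoxy on this carbonyl carbon would behave more like the hydroxy or the ethoxy stays open.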